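From thiophen-3-yl to phenyl in a series at its limit

A few compounds are considered here, and "the series" means these few. Any claim that something is new, unique, unknown or untested is made for them only; others in the source may bear on it.

Values in a functional assay on HepG2 cells (Homo sapiens) for antiproliferative activity, read by XTT assay, with a stated time of 72 h (on this read-out lower numbers stand for stronger inhibition and higher numbers for weaker inhibition), each of them a limit:
Compound 1 `Cc1nc(N)c2c(-c3ccoc3)cn([C@@H]3O[C@H](CO)[C@@H](O)[C@H]3O)c2n1` gives > 20000 nM as a limit
Compound 2 `Cc1nc(N)c2c(-c3cccs3)cn([C@@H]3O[C@H](CO)[C@@H](O)[C@H]3O)c2n1` gives > 20000 nM as a limit
Compound 3 `Cc1nc(N)c2c(-c3ccsc3)cn([C@@H]3O[C@H](CO)[C@@H](O)[C@H]3O)c2n1` gives > 20000 nM as a limit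

Compound 3 stands at the limit of > 20000 nM in this assay, at which 3 of the 3 values shown sit, and so has a limit rather than a number. The change to compound 4 `Cc1nc(N)c2c(-c3ccccc3)cn([C@@H]3O[C@H](CO)[C@@H](O)[C@H]3O)c2n1` is phenyl in place of thiophen-3-yl on an aromatic carbon and puts phenyl in place of thiophen-3-yl on an aromatic carbon. Two swaps of this group bear on it, a step that the two limits leave unreadable from compound 1 to compound 3 and a step that the two limits leave unreadable from compound 2 to compound 3, and neither has a size that can be read. Compound 3 is a limit at > 20000 nM, so no step beyond the scatter is expected in this assay for compound 4. The expected step is a step that the limit leaves unreadable from compound 3 to compound 4 and remains a rough guess. For compound 4 the estimated value is 25000 nM, with an expected range from 12000 nM to 60000 nM and a good chance of another limit.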

Compound 4, half-maximal inhibitory concentration: > 20000 nM
Compound 4: no number, only a limit; the forecaster's own chance of this, stated with the estimate: 85%; the middle value lies beyond the limit too.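

Compound 1, compound 2, compound 3 and compound 4 each give only a limit, so no step between them can be read: the limit of > 20000 nM in this assay, at which 4 of the 4 values shown sit.

The compounds shown leave open whether changing this aromatic ring on the shared core alters activity at all.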